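The compounds below may be only part of what the source reports. "The series", "measured", "known", "first", "only" and "open" are said of these compounds alone.

Among the compounds with values here, compound 2 `CN(c1ccccc1)c1cnc(NCc2c(F)ccc3c2CCO3)n2cnnc12` is the most lipophilic of the three compounds measured so far: in a physicochemical assay for lipophilicity, using the shake flask method, in phosphate buffer, measured as octanol-water partition, with a stated time of 30 min, at pH 7.4 (a higher number here means a more lipophilic compound, a lower number a more polar compound), compound 2 gives 3.6. Compound 1 `CNC(=O)c1ccc(-c2cnc(NCc3c(F)ccc4c3CCO4)c3cn[nH]c(=O)c23)c(C)n1` lies below it, with compound 1 at 2.9, and compound 3 `Cc1nc(CN(C)C)ccc1-c1cnc(NCc2c(F)ccc3c2CCO3)c2cn[nH]c(=O)c12` lies lowest, compound 3 giving 2. Within the data shown here, the only single-point step measured within this set is a number 0.90 log units lower from compound 1 to compound 3 (beyond the scatter), a change on a different part of the shared core. Compound 4 `Fc1ccc2c(c1CNc1ncc(Nc3ccccc3)c3nncn13)CCO2` differs from compound 2 by hydrogen in place of methyl on a nitrogen on an aromatic ring. Among the measured compounds shown here, no measured step covers this kind of change, so the expectation rests on the general size of shifts seen here. Losing one carbon while a hydrogen enters on that nitrogen is expected to lower the number, but less than the step from compound 1 to compound 3 did. The step is estimated as a number 0.40 log units lower from compound 2 to compound 4 (beyond the scatter). Compound 4 is therefore expected to give about 3.2 in this assay, most likely between 2.7 and 3.7.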

Compound 4, distribution coefficient: 3.3
Estimate against measurement, compound 4: 0.10 log units below, within the range that was stated.
By their numbers in this assay, from the lowest: compound 3; then compound 1; then compounds 4 and 2 (each within the scatter of the next).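

Within the data shown here, changing methyl(phenyl)amino to anilino, with hydrogen in place of methyl on a nitrogen on an aromatic ring, gives in this assay a number 0.30 log units lower from compound 2 to compound 4 (within the scatter), the first measured step at this position. On this scale, compound 2 and compound 4 cannot be told apart, so taking away this one methyl does not produce a clear difference in this pair. Nothing measured here offers an explanation for this result.

Still open, on these data alone, is how this nitrogen would respond to a different group, such as ethyl, acetyl or a longer chain carrying an amine or a carboxylic acid. It is also open whether hydrogen in place of methyl would give a similar result on a different core, as only this one matched pair is shown.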